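Branching the Ester Chain of a Thiourea Agonist

The compounds below may be only part of what the source reports. "The series", "measured", "known", "first", "only" and "open" are said of these compounds alone.

Compound 1 `COC(=O)c1c(NC(=S)Nc2cccc3ccccc23)sc2c1CCC2`: 3570 nM in an assay on HEK-Blue hTLR2 cells for agonist activity at Toll-like receptor 2 (Homo sapiens), with a stated time of 24 h; on this read-out higher numbers stand for an effect only at larger amounts of compound and lower numbers for an effect already at smaller amounts.
Compound 2 `CCCOC(=O)c1c(NC(=S)Nc2cccc3ccccc23)sc2c1CCCC2`: 1050 nM in this assay.

Of the two values shown, compound 2 gives the lower one; compound 1 stands apart from it by a gap that lies beyond the scatter. Compound 3 `CC(C)COC(=O)c1c(NC(=S)Nc2cccc3ccccc23)sc2c1CCCC2` has not been measured. It differs from compound 2 by methyl in place of hydrogen on a saturated chain carbon bound to two saturated chain carbons. Within the data shown here, no comparable step between measured compounds is available, so a change of no more than the scatter is expected, in either direction. On that basis compound 3 is estimated at 1000 nM, within 400 nM to 2500 nM. The step this estimate means, a 1.1-fold lower number from compound 2 to compound 3 (0.02 log units; within the scatter), is expected to stay within the scatter.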

Compound 3, half-maximal effective concentration: 30500 nM
For compound 3 the middle estimate is 31-fold (1.48 log units) below the measured one, outside the stated range (above it).
By their numbers in this assay, from the lowest: compound 2; then compound 1; then compound 3.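

In this assay, methyl in place of hydrogen on a saturated chain carbon bound to two saturated chain carbons, which turns propoxy into isobutoxy, gives a 29-fold higher number from compound 2 to compound 3 (1.46 log units; beyond the scatter). The read-out at this place on the ester chain is thus highly sensitive to this single change, something the earlier pair, which differs in more than one place, could not show. Nothing in the available data accounts for this step.

Still open, on these data alone, is whether this step is specific to branching at this carbon or would also appear with an unbranched butyl chain. As far as these compounds go, it is equally open how an isopropyl ester or a terminal amine on the chain would read.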